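Aromatic methyl scan on the bicyclic carboxamide series

The source may report more compounds than this note shows. Statements on the series, on what has been measured and on what is new or still open speak of the compounds shown alone.

Compound 1 `C[C@@H]1Cc2cc(C(N)=O)cnc2N1` gives 42 nM in an assay on isolated protein for inhibition of Nicotinamide N-methyltransferase (Homo sapiens), read by luminescence, with a stated time of 20 min (on this read-out lower numbers stand for stronger inhibition and higher numbers for weaker inhibition), the higher of the two numbers recorded so far. Within the data shown here, compound 2 `C[C@H]1Nc2ncc(C(N)=O)cc2[C@@H]1C` gives 20 nM; the step of a 2.1-fold lower number from compound 1 to compound 2 (0.32 log units; beyond the scatter) is the only measured change in the set. Compound 3 `Cc1c(C(N)=O)cnc2c1C[C@@H](C)N2` differs from compound 1 by methyl in place of hydrogen on an aromatic carbon. Among the measured compounds shown here, no measured step places a methyl on an aromatic carbon, so the step from compound 1 to compound 2 bears on it only loosely. A step of a 1.2-fold higher number from compound 1 to compound 3 (0.08 log units; within the scatter) is expected, within the scatter. Compound 3 is estimated at 50 nM, range 15 nM to 170 nM.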

Compound 3, half-maximal inhibitory concentration: 43 nM
The estimate for compound 3 lay 1.2-fold (0.07 log units) above the measured number, and the stated range covers the measured number.
By their numbers in this assay, from the lowest: compound 2; then compounds 1 and 3 (each within the scatter of the next).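

In this assay the step of a 1.0-fold higher number from compound 1 to compound 3 (0.01 log units; within the scatter) shows that methyl in place of hydrogen on this aromatic carbon, ortho to a carbamoyl group and opposite the ring nitrogen, leaves the number within the scatter. Among these compounds, the earlier step of a 2.1-fold lower number from compound 1 to compound 2 (0.32 log units; beyond the scatter) concerned a saturated ring carbon, so this is the first reading on the aromatic position, and here the added methyl produces no change beyond the scatter. No available evidence accounts for this result. From the compounds shown here alone, whether an ethyl, a methoxy or an amine at this carbon would behave like methyl stays open, as does the effect of pairing this aromatic methyl with the added saturated ring methyl of compound 2.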